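Series notes: 4-aminobutyl in place of isopropyl

The compounds below may be only part of what the source reports. "The series", "measured", "known", "first", "only" and "open" are said of these compounds alone.

Compound 1 `O=C(CN(c1nc(Cl)nc2[nH]cnc12)C1CC1)NCC(=O)OCc1ccccc1` gives 9.93% in a functional assay on the whole organism (Tail, strain ICR) with Mus musculus as the target, in the tail flick test, with a stated time of 90 min, at a dose of 6.25 umol/kg by the oral route; a higher number here means a stronger effect of the compound at the dose given, a lower number a weaker effect. Compound 2 `N=C(N)NCCC[C@H](NC(=O)CN(c1nc(Cl)nc2[nH]cnc12)C1CC1)C(=O)O` gives 12.1% there, and compound 3 `CC(C)[C@H](NC(=O)CN(c1nc(Cl)nc2[nH]cnc12)C1CC1)C(=O)OCc1ccccc1` gives 11.8%. Compound 3 holds the second highest of the three numbers, with compound 2 nearest and compound 1 furthest, both gaps within the scatter. Compound 4 `NCCCC[C@H](NC(=O)CN(c1nc(Cl)nc2[nH]cnc12)C1CC1)C(=O)OCc1ccccc1` differs from compound 3 by 4-aminobutyl in place of isopropyl on a saturated chain carbon bound to an amide-type nitrogen and a carbonyl carbon. For the measured compounds named here, the one measured step at this place, a number 1.9 percentage points higher from compound 1 to compound 3 (within the scatter), stayed within the scatter, and compound 2, carrying another chain at the same place, sits within the scatter of both. Going by the values given here, no measured step involves the entering 4-aminobutyl. Compound 4 is therefore expected to show no step beyond the scatter, a number 0.2 percentage points higher from compound 3 to compound 4 (within the scatter), with an estimate of 12% between 3% and 25%.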

Compound 4, a percentage reported as activity, at one dose (the size of the read-out at that dose, not a potency): 11.3%
Compound 4: the middle estimate sits 0.7 percentage points above what was measured; low and high end bracket the measured number.
By their numbers in this assay, from the lowest: compounds 1, 4, 3 and 2 (each within the scatter of the next).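

In this assay, 4-aminobutyl gives a number 0.5 percentage points lower from compound 3 to compound 4 (within the scatter) and so does not separate from isopropyl at this saturated chain carbon, even with an amine in the chain. Set against hydrogen at the same place, it gives a number 1.4 percentage points higher from compound 1 to compound 4 (within the scatter) and again stays within the scatter. No measured evidence bears on this result.

Open, from the compounds shown here alone, is whether a longer chain, a phenyl ring or a carboxylic acid in place of the amine would move the read-out beyond the scatter. One dose at one time also shows only the size of the effect at that dose.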